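The compounds below may be only part of what the source reports. "The series", "measured", "known", "first", "only" and "open" are said of these compounds alone.

Compound 1 `Clc1cccc(Oc2cncc(C3=CC4CNCC(C3)C4)c2)c1` gives 22 nM in an in vitro assay on SH-SY5Y cells for displacement of a labelled ligand from Neuronal acetylcholine receptor; alpha3/beta4 (Homo sapiens); a higher number here means a weaker inhibitor, a lower number a stronger inhibitor.
Compound 2 `COc1cc(C2=CC3CNCC(C2)C3)cnc1Cl` gives 7 nM in this assay.
Compound 3 `C1=C(c2ccc(-c3ccccc3)nc2)CC2CNCC1C2` gives 507 nM in this assay.

Among these three numbers compound 1 stands second highest: compound 2 sits lower by a step beyond the scatter, and compound 3 sits far higher, also beyond the scatter. Compound 4 `C1=C(c2cncc(OCc3ccccc3)c2)CC2CNCC1C2` differs from compound 1 in one place: benzyl in place of 3-chlorophenyl on an oxygen on an aromatic ring. No pair of measured compounds shows this change, so its size is unknown from the data shown. A modest rise in the number is expected, small enough that it may fall within the scatter. Compound 4 is estimated at 40 nM, with a range from 10 nM to 160 nM. That estimate means an expected step of a 1.8-fold higher number from compound 1 to compound 4 (0.26 log units; within the scatter).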

Compound 4, inhibition constant: 44 nM
Compound 4: middle estimate off by 1.1-fold (0.04 log units), on the low side; the range from low to high includes it.
By their numbers in this assay, from the lowest: compound 2; then compounds 1 and 4 (each within the scatter of the next); then compound 3.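

In this assay, benzyl in place of 3-chlorophenyl on an oxygen on an aromatic ring gives a 2.0-fold higher number from compound 1 to compound 4 (0.30 log units; within the scatter) and so leaves the number within the scatter. At this place, therefore, the two groups cannot be told apart in this read-out, though they differ in both the chlorine and the way the ring is attached. Nothing measured here explains this likeness. Plain phenyl or 3-chlorobenzyl on the same oxygen would be needed to separate those two differences. As far as these compounds go, whether a longer chain such as phenethyl, or an amine on the ring, fits here remains open.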